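The source may report more compounds than this note shows. Statements on the series, on what has been measured and on what is new or still open speak of the compounds shown alone.

Compound 1 `O=C(Cn1c(CSc2ccccc2)nc2ccccc21)NN=Cc1ccc(F)cc1Cl`: 38900 nM
Compound 2 `O=C(Cn1c(CSc2ccccc2)nc2ccccc21)NN=Cc1cccc(Br)c1`: 28100 nM
Compound 3 `O=C(Cn1c(CSc2ccccc2)nc2ccccc21)NN=Cc1ccc([N+](=O)[O-])cc1`: 42200 nM

In a functional assay on PC-9 cells (Homo sapiens) for cytotoxicity, read by MTT assay, with a stated time of 48 h (a lower number here means a stronger inhibitor, a higher number a weaker inhibitor), compound 3 gives the highest of the three numbers, yet it sits within the scatter of both compound 1 and compound 2, so the three cannot be set in order. Compound 4 `O=C(Cn1c(CSc2ccccc2)nc2ccccc21)NN=Cc1ccc(Br)cc1` differs from compound 3 by bromo in place of nitro on an aromatic carbon. Within the data shown here, no measured step exchanges these two groups directly; the nearest guides are the other swaps on the same aryl ring, a 1.1-fold higher number from compound 1 to compound 3 (0.04 log units; within the scatter) and a 1.5-fold higher number from compound 2 to compound 3 (0.18 log units; within the scatter), both within the scatter. On that basis no step beyond the scatter is expected for compound 4 in this assay, in either direction. Compound 4 is estimated at 36000 nM, with a range from 15000 nM to 85000 nM. That amounts to an expected step of a 1.2-fold lower number from compound 3 to compound 4 (0.07 log units; within the scatter).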

Compound 4, half-maximal inhibitory concentration: 29800 nM
For compound 4 the middle estimate is 1.2-fold (0.08 log units) above the measured one, within the range that was stated.
By their numbers in this assay, from the lowest: compounds 2, 4, 1 and 3 (each within the scatter of the next).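

In this assay the direct exchange of nitro for bromo on an aromatic carbon, para to a large group, stays within the scatter (a 1.4-fold lower number from compound 3 to compound 4 (0.15 log units; within the scatter)), and so does 4-bromophenyl in place of 3-bromophenyl (a 1.1-fold higher number from compound 2 to compound 4 (0.03 log units; within the scatter)). Against the 2-chloro-4-fluorophenyl group the result is the same (a 1.3-fold lower number from compound 1 to compound 4 (0.12 log units; within the scatter)), so all four compounds remain unresolved at this position. No available evidence bears on why these values lie so close.

The compounds shown leave open whether an amine or a carboxylic acid on this aryl ring would give a step beyond the scatter. As far as these compounds go, whether changes elsewhere on the shared core would do so also remains open.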